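The source may hold more compounds than are shown below. What is called first, only, known or untested is meant among the compounds shown, and "the series" means these compounds.

Compound 3 `N/C(=N\NC(=S)N1CCCC1)c1ccccn1` stands second highest of the three numbers recorded in a functional assay on HeLa cells (Homo sapiens) for cytotoxicity, read by MTT assay, with a stated time of 72 h, tested at 100 uM (on this read-out higher numbers stand for more inhibition of growth at the one concentration tested and lower numbers for less inhibition of growth), where compound 3 gives 89.1%. Its nearest neighbour is compound 1 `Cc1ccnc(/C(N)=N/NC(=S)N2CCSCC2)c1`, which in this assay gives 91.6%, and its furthest is compound 2 `N/C(=N\NC(=S)N1CCCCC1)c1ccccn1`, which gives 86%; all three lie within the scatter of one another. Within the data shown here, the single measured step, a number 3.1 percentage points higher from compound 2 to compound 3 (within the scatter), shows that exchanging the ring on the thiocarbonyl carbon left the read-out unchanged within the scatter. Compound 4 `Cc1ccnc(/C(N)=N/NC(=S)N2CCCC2)c1` differs from compound 3 by methyl in place of hydrogen on an aromatic carbon. Among the measured compounds shown here, no measured pair isolates this change: compound 1 carries the methyl and compound 3 does not, but they also differ in the ring on the thiocarbonyl carbon, and their two values lie within the scatter of each other. For the measured compounds named here, every measured number so far sits near the top of the scale. Compound 4 is therefore expected to give 90%, within a range from 80% to 97%. The step of a number 0.9 percentage points higher from compound 3 to compound 4 (within the scatter) is expected to remain within the scatter.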

Compound 4, percent growth inhibition at one concentration: 88.1%
Compound 4: middle estimate off by 1.9 percentage points, on the high side; the range from low to high includes it.
By their numbers in this assay, from the lowest: compounds 2, 4, 3 and 1 (each within the scatter of the next).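

In this assay the step of a number 1 percentage points lower from compound 3 to compound 4 (within the scatter) isolates methyl in place of hydrogen on an aromatic carbon, opposite the ring nitrogen, and shows that this change leaves the read-out unchanged within the scatter. With that methyl present on both compounds, the step of a number 3.5 percentage points lower from compound 1 to compound 4 (within the scatter) also isolates pyrrolidin-1-yl in place of thiomorpholin-4-yl on the thiocarbonyl carbon, and this exchange likewise leaves the read-out within the scatter. No evidence is available on why either change leaves the number where it is.

All four compounds sit near the top of the scale at the single concentration tested, which leaves open how far they would separate at lower concentrations. As far as these compounds go, whether an amine, a carboxylic acid or a longer chain such as ethyl at this position would move the number also remains open.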